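The source may hold more compounds than are shown below. What is called first, only, known or untested is meant among the compounds shown, and "the series" means these compounds.

Measured compounds:
compound 1, `C=CCn1nc(-c2cccnc2)c2ccccc2c1=O`: 2140 nM
compound 2, `O=C(O)CCCn1nc(-c2cccnc2)c2ccccc2c1=O`: > 100000 nM

In a functional assay (trachea) with Cavia porcellus as the target (on this read-out lower numbers stand for stronger inhibition and higher numbers for weaker inhibition), compound 1 gives 2140 nM, the only number shown on this read-out. Compound 2 returns only > 100000 nM, which is a limit of the assay and not a number (the limit of > 100000 nM in this assay, at which 1 of the 2 values shown sits). Among the compounds with values here, the one measured step, an at least 46-fold higher number from compound 1 to compound 2 (1.66 log units; beyond the scatter), thus runs up to the limit of the assay.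

Compound 3, `O=C(O)c1ccc(Cn2nc(-c3cccnc3)c3ccccc3c2=O)cc1`, remains to be measured in this assay. It differs from compound 1 as 4-carboxyphenyl in place of vinyl on a saturated chain carbon bound to an aromatic nitrogen. The change shares with the step to compound 2 the loss of vinyl and the arrival of a group carrying a carboxy function on the saturated chain carbon bound to the aromatic nitrogen; it differs in that a six-membered aromatic ring of carbon only, not a chain, holds the acid. Within the data shown here, the only step that bears on it, an at least 46-fold higher number from compound 1 to compound 2 (1.66 log units; beyond the scatter), was large and beyond the scatter. A large loss is therefore expected for compound 3 in this assay, a 23-fold higher number from compound 1 to compound 3 (1.37 log units; beyond the scatter), with a fair chance that only a limit is returned. The estimate for compound 3 is 50000 nM, in the range 6000 nM to 400000 nM.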

Compound 3, half-maximal inhibitory concentration: 17000 nM
Compound 3: the middle estimate sits 2.9-fold (0.47 log units) above what was measured; measured number inside the range.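

In this assay, a carboxylic acid on the group at this saturated chain carbon bound to an aromatic nitrogen does not by itself take the read-out to the limit: 4-carboxyphenyl in place of vinyl gives a 7.9-fold higher number from compound 1 to compound 3 (0.90 log units; beyond the scatter), a modest loss that still leaves a measured number. What carries the acid therefore makes a difference in this pair, since 4-carboxyphenyl in place of 2-carboxyethyl gives an at least 5.8-fold lower number from compound 2 to compound 3 (0.76 log units; beyond the scatter). Compound 2 gives a limit of the assay and not a number, so this second step has a bound only: the limit of > 100000 nM in this assay, at which 1 of the 3 values shown sits.

With three compounds, the loss from vinyl to 4-carboxyphenyl cannot be divided between the added phenyl ring and its carboxylic acid, and an unsubstituted phenyl or a methyl ester on the same carbon would separate the two. As far as these compounds go, it also remains open whether the difference between compound 2 and compound 3 follows from the ring itself or from the length of the link to the acid, which a longer chain ending in a carboxylic acid or a primary amide on the phenyl ring could begin to test.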